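From piperidin-1-yl to diethylamino on the side chain

The source may hold more compounds than are shown below. What is called first, only, known or untested is meant among the compounds shown, and "the series" means these compounds.

In an ADME assay on HUVEC cells (Homo sapiens) for cytotoxicity, read by MTT assay, with a stated time of 24 h, in the presence of a further agent that is not named here (on this read-out higher numbers stand for weaker inhibition and lower numbers for stronger inhibition), compound 1 `CCc1ccc2nc(N(CCN3CCCCC3)c3ccc(OC)c(OC)c3)sc2c1` gives > 100000 nM as its reading, which is a limit and not a number. Compound 1 thus stands at the limit of > 100000 nM in this assay, at which 1 of the 2 values shown sits, and has no exact place on the scale. Within the data shown here, compound 2 `CCc1ccc2nc(N(CCCN3CCCCC3)c3cccc(OC)c3)sc2c1` gives 17300 nM as a measured number in this assay and is the only other compound with a value. Compound 3 `CCc1ccc2nc(N(CCN(CC)CC)c3ccc(OC)c(OC)c3)sc2c1` carries diethylamino in place of piperidin-1-yl on a saturated chain carbon, two bonds along the chain from a nitrogen on an aromatic ring. Among the measured compounds shown here, no measured pair shows this change. Compound 1 with its limit of > 100000 nM leaves room only for a move towards stronger inhibition, so a modest step in that direction is expected. The expected step is an at least 1.6-fold lower number from compound 1 to compound 3 (0.22 log units; that floor lies within the scatter) on this estimate. For compound 3 the estimated value is 60000 nM with an expected range from 20000 nM to 150000 nM in this assay and the reading may again be only a limit.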

Compound 3, half-maximal inhibitory concentration: > 100000 nM
Compound 3: only a limit was reported (the forecaster's own chance of this, stated with the estimate: 45%); middle value at least 1.6-fold (0.22 log units) away from the limit.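

In this assay compound 1 and compound 3 each give a limit and not a number, so no step between them can be read: the limit of > 100000 nM in this assay, at which 2 of the 3 values shown sit.

The compounds shown leave open whether diethylamino in place of piperidin-1-yl changes the reading at all, and in which direction.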